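Methoxy in place of nitro on the aryl group of compound 2

This account rests on a few compounds, and the source may have more. Where it says the series, first, only, none or still open, it means among the compounds named here.

In a functional assay on DU-145 cells (Homo sapiens) for cytotoxicity, read by sulforhodamine B assay, with a stated time of 2 days, tested at 100 uM (on this read-out higher numbers stand for more inhibition at the one concentration tested (going by the name of the read-out) and lower numbers for less inhibition), compound 2 `O=C(Nn1c(-c2cccc([N+](=O)[O-])c2)nc2c(-c3ccc(Cl)cc3)n[nH]c2c1=O)c1ccccc1` gives 94.3%, the highest of the two numbers at hand, though compound 1 `COc1cccc(-c2nc3c(-c4cccc(Cl)c4)n[nH]c3c(=O)n2NC(=O)c2ccccc2)c1` at 93.5% lies within the scatter of it and no order between the two can be claimed. Among the measured compounds shown here, compound 3 `COc1cccc(-c2nc3c(-c4ccc(Cl)cc4)n[nH]c3c(=O)n2NC(=O)c2ccccc2)c1` is compound 2 with methoxy in place of nitro on an aromatic carbon; no measured pair shows this change alone. Because compound 1 already carries a methoxy group and gives 93.5%, the step is expected to be small, a number 1.3 percentage points lower from compound 2 to compound 3 (within the scatter), none beyond the scatter. Compound 3 is expected to give 93%, range 84% to 98%.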

Compound 3, a percentage reported as inhibition, at one concentration (the size of the read-out at that concentration, not a potency): 94.1%
For compound 3 the middle estimate is 1.1 percentage points below the measured one; the measured number falls inside the stated range.
By their numbers in this assay, from the lowest: compounds 1, 3 and 2 (each within the scatter of the next).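

In this assay the change from 3-nitrophenyl to 3-methoxyphenyl now has a measured pair, with a number 0.2 percentage points lower from compound 2 to compound 3 (within the scatter) and no readable effect of this exchange at this position. The pair for 4-chlorophenyl in place of 3-chlorophenyl gives a number 0.6 percentage points higher from compound 1 to compound 3 (within the scatter) and likewise shows no readable change at that aromatic carbon. No evidence at hand bears on these results.

From the compounds shown here alone, whether an amine or a carboxylic acid at the same aromatic carbon would move the number remains open. The single concentration also leaves open how these compounds compare at lower concentrations.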